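Replacing an Amide Link by a Urea Link

The source may hold more compounds than are shown below. What is called first, only, known or untested is meant among the compounds shown, and "the series" means these compounds.

Compound 1 `COc1cc(-c2nn(-c3cccc(NC(=O)c4cccc(C(F)(F)F)c4)c3)cc2-c2ccncc2)ccc1Cl` and compound 2 `O=C(Nc1cccc(-n2cc(-c3ccncc3)c(-c3ccc(Cl)c(O)c3)n2)c1)Nc1ccc(Cl)c(C(F)(F)F)c1` were tested in a functional assay on SK-MEL-5 cells (Homo sapiens) for inhibition, read by sulforhodamine B assay, with a stated time of 48 h; on this read-out lower numbers stand for higher toxicity in this test and higher numbers for lower toxicity in this test. Compound 1 gives 40600 nM, the highest of the two numbers, while compound 2 gives 2130 nM, a gap beyond the usual scatter. Compound 3 `COc1cc(-c2nn(-c3cccc(NC(=O)Nc4ccc(Cl)c(Cl)c4)c3)cc2-c2ccncc2)ccc1Cl` is not yet measured; it differs from compound 1 by (3,4-dichlorophenyl)amino in place of 3-(trifluoromethyl)phenyl on a carbonyl carbon. The change moves toward a urea linkage, as in compound 2, whose lower number suggests the direction. A decrease beyond the scatter, a 6.8-fold lower number from compound 1 to compound 3 (0.83 log units; beyond the scatter), is expected, giving compound 3 an estimated 6000 nM, likely between 1500 nM and 25000 nM.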

Compound 3, concentration lethal to 50% of the cells: 3020 nM
Compound 3: middle estimate off by 2.0-fold (0.30 log units), on the high side; measured number inside the range.
By their numbers in this assay, from the lowest: compounds 2 and 3 (each within the scatter of the next); then compound 1.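

In this assay, among the compounds shown here, the single change at this carbonyl carbon gives a 13-fold lower number from compound 1 to compound 3 (1.13 log units; beyond the scatter), a large step toward higher toxicity in this test. Compound 1 and compound 2 differ in more than one place, whereas this pair ties a gap of this kind to one place on the shared core. On these data alone, the swap brings in the amino nitrogen and the two chlorines together, so their separate shares remain unknown. A phenylamino group on the same carbonyl carbon would help to separate them. No measured evidence here explains the step.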